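Aryl sulfone variation on the shared core: step to compound 4

This account rests on a few compounds, and the source may have more. Where it says the series, first, only, none or still open, it means among the compounds named here.

Three compounds share one core and differ only in the aryl group on the sulfonyl sulfur. Compound 1 `Cc1ccc(S(=O)(=O)c2cnc3ccc(F)cc3c2N2CCC(C)CC2)cc1` carries a 4-methylphenyl group; in an assay on isolated protein for displacement of a labelled ligand from metabotropic glutamate receptor 5 (Homo sapiens), with a stated time of 60 min, tested at 1 uM (on this read-out lower numbers stand for less inhibition and higher numbers for more inhibition at the one concentration tested (going by the name of the read-out)), compound 1 gives 91%. Compound 2 `COc1ccc(S(=O)(=O)c2cnc3ccc(F)cc3c2N2CCC(C)CC2)cc1` carries a 4-methoxyphenyl group, and in this assay compound 2 gives 85%. Compound 3 `Cc1cc(C)cc(S(=O)(=O)c2cnc3ccc(F)cc3c2N2CCC(C)CC2)c1` carries a 3,5-dimethylphenyl group, and in this assay compound 3 gives 83%. On these numbers compound 3 sits at the low end, but the gaps are small: a number 8 percentage points lower from compound 1 to compound 3 (within the scatter) and a number 2 percentage points lower from compound 2 to compound 3 (within the scatter). Likewise a number 6 percentage points lower from compound 1 to compound 2 (within the scatter).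

Compound 4 `COc1ccc(S(=O)(=O)c2cnc3ccc(F)cc3c2N2CCC(C)CC2)cc1Cl` has not been measured. It differs from compound 3 in one place: 3-chloro-4-methoxyphenyl in place of 3,5-dimethylphenyl on a sulfonyl sulfur. The measured step that bears most on it is a number 2 percentage points lower from compound 2 to compound 3 (within the scatter); compound 4 brings back the methoxy group and adds a chlorine. The step of a number 8 percentage points lower from compound 1 to compound 3 (within the scatter) also shows that varying this aryl group has so far moved the read-out only within the scatter. For the measured compounds named here, no measured pair isolates the chlorine. The expected step in this assay is therefore a number 3 percentage points higher from compound 3 to compound 4 (within the scatter), none beyond the scatter. Compound 4 is estimated at 86%, with a range from 75% to 95%.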

Compound 4, a percentage reported as inhibition, at one concentration (the size of the read-out at that concentration, not a potency): 82%
Compound 4: middle estimate off by 4 percentage points, on the high side; measured number inside the range.
By their numbers in this assay, from the lowest: compounds 4, 3, 2 and 1 (each within the scatter of the next).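

For the compounds shown here, compound 2 and compound 4 form the first pair that isolates the chlorine: in this assay, chloro in place of hydrogen on an aromatic carbon gives a number 3 percentage points lower from compound 2 to compound 4 (within the scatter), so this addition to the 4-methoxyphenyl group does not move the read-out beyond the scatter. The 3-chloro-4-methoxyphenyl group, which enters with more heavy atoms and one hydrogen-bond acceptor where 3,5-dimethylphenyl has none, also stays within the scatter of the other aryl groups, with a number 1 percentage points lower from compound 3 to compound 4 (within the scatter) and a number 9 percentage points lower from compound 1 to compound 4 (within the scatter), so all four aryl groups on the sulfonyl sulfur remain indistinguishable in this read-out. No independent measurement bears on why the number stays level across these changes.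

From the compounds shown here alone, whether a dimethylamino group or a carboxylic acid on the aryl ring, or a longer alkyl chain in place of the aryl group on the sulfonyl sulfur, would give a step beyond the scatter remains open. Also open, going by these compounds, is how these four compounds rank in potency, as a percentage at one concentration does not separate them on that measure.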